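Benzyl triazole ethers: a methoxyphenyl variant

The compounds below may be only part of what the source reports. "The series", "measured", "known", "first", "only" and "open" are said of these compounds alone.

Measured so far:
compound 1 `Cc1cccc(Cn2cc(COc3ccc4c(=O)ccoc4c3)nn2)c1` — 16000 nM
compound 2 `N#Cc1ccc(Cn2cc(COc3ccc4c(=O)ccoc4c3)nn2)cc1` — > 100000 nM
compound 3 `O=c1ccoc2cc(OCc3cn(Cc4ccccc4Cl)nn3)ccc12` — 15100 nM

In a functional assay on MDA-MB-231 cells (Homo sapiens) for cytotoxicity, read by MTT assay, with a stated time of 48 h (a lower number here means a stronger inhibitor, a higher number a weaker inhibitor), compound 1 gives 16000 nM, the highest of the two numbers shown. Compound 3 sits close, with a 1.1-fold lower number from compound 1 to compound 3 (0.03 log units; within the scatter). Compound 2 reports only a limit of the assay, (the limit of > 100000 nM in this assay, at which 1 of the 3 values shown sits). The steps through compound 2 are large: an at least 6.2-fold higher number from compound 1 to compound 2 (0.79 log units; beyond the scatter) and an at least 6.6-fold lower number from compound 2 to compound 3 (0.82 log units; beyond the scatter).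

Compound 4 `COc1ccc(Cn2cc(COc3ccc4c(=O)ccoc4c3)nn2)cc1` differs from compound 1 by 4-methoxyphenyl in place of 3-methylphenyl on a saturated chain carbon bound to an aromatic nitrogen. Among the measured compounds shown here, two measured steps bear on it. The move from compound 1 to compound 3 shows that swapping the substituent on the phenyl ring can leave the number unchanged within scatter, whereas the move from compound 1 to compound 2, also a 4-substituted phenyl entering, shows a rise beyond the scatter. A 4-methoxyphenyl is neither of these groups, so the expected step is a modest rise at most, with wide uncertainty.

Compound 4 is therefore expected to give 25000 nM, in the range 10000 nM to 100000 nM, corresponding to an estimated 1.6-fold higher number from compound 1 to compound 4 (0.19 log units; within the scatter).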

Compound 4, half-maximal inhibitory concentration: > 100000 nM
Compound 4: a limit, no number; the forecaster's own chance of this, stated with the estimate: 25%; middle value at least 4.0-fold (0.60 log units) from the limit.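

In this assay the result for compound 4 is a limit, not a number, and it is the second value in the series at that limit: the limit of > 100000 nM in this assay, at which 2 of the 4 values shown sit.

Replacing 3-methylphenyl or 2-chlorophenyl with 4-methoxyphenyl gives an at least 6.2-fold higher number from compound 1 to compound 4 (0.79 log units; beyond the scatter) and an at least 6.6-fold higher number from compound 3 to compound 4 (0.82 log units; beyond the scatter), so the jump seen with the 4-cyanophenyl of compound 2 is not unique to that group. Among the compounds shown, both with a 4-substituted phenyl, compound 2 and compound 4, sit at the limit, and both others, compound 1 and compound 3, give measured numbers, with no exception in this small set.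

The step between compound 2 and compound 4 cannot be read, so nitrile and methoxy remain unranked. Going by these compounds, whether the trend holds for other 4-substituted phenyl groups, such as 4-aminophenyl or 4-carboxyphenyl, stays open, as does the effect of 3-methoxyphenyl.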